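Swapping Chloro for Methyl on the Benzyl Group

The source may hold more compounds than are shown below. What is called first, only, known or untested is meant among the compounds shown, and "the series" means these compounds.

Measured compounds:
compound 1 `COc1cc(Oc2cccc(Nc3ccccc3)c2)cc(OC)c1CNCc1ccc(Br)cc1`: 6230 nM
compound 2 `COc1cc(Oc2cccc(Nc3ccccc3)c2)cc(OC)c1CNCc1ccc(Cl)cc1`: 3310 nM
compound 3 `CNCc1c(OC)cc(Oc2cccc(Nc3ccccc3)c2)cc1OC`: > 20000 nM

In a functional assay on HCT-116 cells (Homo sapiens) for inhibition, read by MTT assay, with a stated time of 72 h (on this read-out higher numbers stand for weaker inhibition and lower numbers for stronger inhibition), compound 2 gives 3310 nM, the lowest of the two plain numbers. Compound 1 gives 6230 nM, and the step of a 1.9-fold lower number from compound 1 to compound 2 (0.27 log units; within the scatter) lies within the scatter, so these two cannot be ranked. For compound 3 the assay reports only a limit, > 20000 nM (the limit of > 20000 nM in this assay, at which 1 of the 3 values shown sits). The steps of an at least 3.2-fold higher number from compound 1 to compound 3 (0.50 log units; beyond the scatter) and an at least 6.0-fold higher number from compound 2 to compound 3 (0.78 log units; beyond the scatter) show that losing the whole halophenyl piece weakens inhibition at least modestly.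

Compound 4 `COc1cc(Oc2cccc(Nc3ccccc3)c2)cc(OC)c1CNCc1ccc(C)cc1` differs from compound 2 by methyl in place of chloro on an aromatic carbon. For the measured compounds named here, the benzyl piece itself stays, which the removals show matters; the only swap measured between two groups on that aromatic carbon, from bromo to chloro, stayed within the scatter. Going by the values given here, no measured step swaps a halogen for methyl, so the expectation is a number close to that of compound 2, with a step of a 1.2-fold higher number from compound 2 to compound 4 (0.08 log units; within the scatter) not clearly beyond the scatter. Compound 4 is therefore estimated at 4000 nM, in a range from 1500 nM to 12000 nM.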

Compound 4, half-maximal inhibitory concentration: 13800 nM
Compound 4: middle estimate off by 3.5-fold (0.54 log units), on the low side; the measured number lies above the stated range.
By their numbers in this assay, from the lowest: compounds 2 and 1 (each within the scatter of the next); then compound 4. At a limit, above all of these: compound 3.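

At this aromatic carbon, para to a large group, the choice of group does matter in this assay: methyl in place of chloro gives a 4.2-fold higher number from compound 2 to compound 4 (0.62 log units; beyond the scatter), and methyl in place of bromo gives a 2.2-fold higher number from compound 1 to compound 4 (0.35 log units; beyond the scatter). The earlier chloro-for-bromo swap stayed within the scatter, so a difference at this carbon shows up only once methyl enters, even though methyl and chloro match in heavy atom count and neither carries a hydrogen-bond donor or acceptor. 4-Methylphenyl in place of hydrogen gives an at least 1.4-fold lower number from compound 3 to compound 4 (0.16 log units; that floor lies within the scatter), a step that starts from a limit and whose floor lies within the scatter, so it settles no order: the limit of > 20000 nM in this assay, at which 1 of the 4 values shown sits.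

Going by these compounds, whether fluoro, methoxy or trifluoromethyl at this carbon would sit with the halogens or with methyl remains open. The compounds shown also leave open what separates methyl from chloro and bromo here.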